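The source may report more compounds than this note shows. Statements on the series, on what has been measured and on what is new or still open speak of the compounds shown alone.

Compound 2, `CCC/C=C/C(=O)Nc1cc2c(N3CCc4ccccc43)ncnc2cc1OC`, gives 4240 nM in a functional assay on PC-3 cells (Homo sapiens) for antiproliferative activity, read by MTT assay, with a stated time of 72 h; a lower number here means a stronger inhibitor, a higher number a weaker inhibitor. Within the data shown here, its only measured neighbour is compound 1, `C=CC(=O)Nc1cc2c(N3CCc4ccccc43)ncnc2cc1OC`, which in this assay gives 5940 nM; the step of a 1.4-fold lower number from compound 1 to compound 2 (0.15 log units; within the scatter) separates them, so the two numbers sit within the usual scatter of each other and neither can be called the stronger inhibitor.

The next compound, compound 3, `COc1cc2ncnc(N3CCc4ccccc43)c2cc1NC(=O)/C=C/CN(C)C`, differs from compound 2 in one place: dimethylamino in place of ethyl on a saturated chain carbon bound to a double-bonded chain carbon. The chain on the carbonyl keeps its double bond and its length, but its outer end now carries a nitrogen.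

Among the measured compounds shown here, the one measured step, from compound 1 to compound 2, also altered this chain, lengthening vinyl to pent-1-en-1-yl, and it stayed within the scatter. For the measured compounds named here, no measured step puts a dimethylamino group onto this chain, so nothing in the data points to a large shift either way. The expected step from compound 2 to compound 3 is therefore a 1.2-fold lower number from compound 2 to compound 3 (0.08 log units; within the scatter), no more than the scatter would allow. Compound 3 is estimated to give 3500 nM in this assay, with a plausible range from 1200 nM to 10000 nM.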

Compound 3, half-maximal inhibitory concentration: 2190 nM
The estimate for compound 3 lay 1.6-fold (0.20 log units) above the measured number; low and high end bracket the measured number.
By their numbers in this assay, from the lowest: compounds 3, 2 and 1 (each within the scatter of the next, the first and the last beyond it).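

In this assay, among these compounds, a nitrogen at the outer end of the chain on the carbonyl produces the first step in this small set to pass the scatter: set against the vinyl group, the result is a 2.7-fold lower number from compound 1 to compound 3 (0.43 log units; beyond the scatter). Measured against the carbon-only chain of compound 2, dimethylamino in place of ethyl gives a 1.9-fold lower number from compound 2 to compound 3 (0.29 log units; within the scatter), which stays within the scatter, so the clear difference appears only against the short vinyl group and compound 3 cannot be ranked ahead of compound 2. No evidence is available here on what lies behind either step.

From the compounds shown here alone, with dimethylamino as the only amine on this chain, it remains open whether the nitrogen matters in itself or whether other end groups, such as diethylamino, a primary amine or a hydroxyl group, would give similar numbers. Also open, going by these compounds, is how much the chain's double bond contributes, which a fully saturated chain carrying the same dimethylamino group would help to show.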